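The compounds below may be only part of what the source reports. "The series", "measured", "known", "first", "only" and "open" are said of these compounds alone.

Measured so far in an ADME assay on MDCK cells (Canis lupus familiaris) for cytotoxicity, read by MTT assay, with a stated time of 48 h; a higher number here means that more compound is tolerated, a lower number that less compound is tolerated:
- compound 1, `COc1ccc([C@H]2CC(C)(F)[C@@H]3CC[C@@H](C)C[C@H]3O2)cc1`, gives 171000 nM
- compound 2, `COc1ccc([C@H]2CC(C)(F)[C@@H]3CC[C@@H](C)C[C@H]3O2)cc1OC`, gives 20000 nM

Among the measured compounds shown here, compound 1 stands highest of these two numbers; its only neighbour is compound 2, with an 8.6-fold lower number from compound 1 to compound 2 (0.93 log units; beyond the scatter). The new compound 3, `C[C@@H]1CC[C@@H]2[C@@H](C1)O[C@@H](c1ccc([N+](=O)[O-])cc1)CC2(C)F`, comes from compound 1 by nitro in place of methoxy on an aromatic carbon. For the measured compounds named here, the one step measured so far, an 8.6-fold lower number from compound 1 to compound 2 (0.93 log units; beyond the scatter), touched the same aromatic ring, but it added a methoxy group while keeping the first one, whereas here a methoxy group is exchanged for a nitro group. Going by the values given here, it therefore speaks only loosely to the present change, and no measured compound carries a nitro group. A drop of similar size in this assay and no change beyond the scatter both remain plausible. Compound 3 is thus expected at about 90000 nM, in a range from 25000 nM to 300000 nM, which corresponds to an expected step of a 1.9-fold lower number from compound 1 to compound 3 (0.28 log units; within the scatter).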

Compound 3, half-maximal cytotoxic concentration: > 976000 nM
Compound 3: a limit, no number; the forecaster's own chance of this, stated with the estimate: 20%; middle value at least 10-fold (1.03 log units) away from the limit.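

Among the compounds shown here, until now, the only change on the aromatic ring of compound 1 had lowered the number. Exchanging the methoxy group for nitro on the aromatic carbon para to a large group moves it the other way in this assay, with an at least 5.7-fold higher number from compound 1 to compound 3 (0.75 log units; beyond the scatter). Changes on this ring can therefore shift the number in either direction, and the methoxy group of compound 1 is not needed for a high number. The value of compound 3 is a limit and not a number: the limit of > 976000 nM in this assay, at which 1 of the 3 values shown sits.

As far as these compounds go, it remains open whether the rise comes from the nitro group itself or simply from losing the methoxy group, and a plain hydrogen, an amine or a carboxylic acid on that carbon would help separate the two. From the compounds shown here alone, how a nitro group would behave on another carbon of the ring is also open.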